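Relocating a Methoxy Group on an Aryl Ether Side Chain

The source may report more compounds than this note shows. Statements on the series, on what has been measured and on what is new or still open speak of the compounds shown alone.

Measured so far:
compound 1, `COc1ccc(C2SC(C)C(=O)Nc3c2c(C)nn3-c2ccccc2C)c(OC)c1`: 10500 nM
compound 2, `COc1ccc(Oc2ccc([C@H]3S[C@@H](C)C(=O)Nc4c3c(C)nn4-c3ccccc3C)cc2)cc1`: 2200 nM

Of the compounds shown here, two have been tested in an assay on isolated protein for agonist activity at Bile acid receptor (Homo sapiens), read by AlphaScreen, with a stated time of 30 min; a lower number here means that less compound is needed, a higher number that more compound is needed for the effect. Compound 1 `COc1ccc(C2SC(C)C(=O)Nc3c2c(C)nn3-c2ccccc2C)c(OC)c1` gives 10500 nM. Compound 2 `COc1ccc(Oc2ccc([C@H]3S[C@@H](C)C(=O)Nc4c3c(C)nn4-c3ccccc3C)cc2)cc1` gives 2200 nM, the lower of the two numbers, and its gap to compound 1 lies beyond the usual scatter of this measurement. Both share the same core and differ only in the aryl group attached to it.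

Compound 3 `COc1ccccc1Oc1ccc([C@H]2S[C@@H](C)C(=O)Nc3c2c(C)nn3-c2ccccc2C)cc1` has not yet been measured in this assay. It differs from compound 2 by 2-methoxyphenyl in place of 4-methoxyphenyl on an oxygen on an aromatic ring. Among the compounds with values here, no measured pair shows what such a rearrangement does here, so the direction of the step is uncertain, and only a modest change is expected, most likely a slight weakening. The expected step is a 1.6-fold higher number from compound 2 to compound 3 (0.20 log units; within the scatter). For compound 3 the estimate is 3500 nM, with a range from 1200 nM to 10000 nM.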

Compound 3, half-maximal effective concentration: 1700 nM
The estimate for compound 3 lay 2.1-fold (0.31 log units) above the measured number; measured number inside the range.
By their numbers in this assay, from the lowest: compounds 3 and 2 (each within the scatter of the next); then compound 1.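

In this assay, 2-methoxyphenyl in place of 4-methoxyphenyl on an oxygen on an aromatic ring gives a 1.3-fold lower number from compound 2 to compound 3 (0.11 log units; within the scatter), so the two compounds cannot be told apart. Within the data shown here, for this pair, then, relocating the methoxy group leaves the number within the usual scatter of repeated measurements, which the earlier compounds could not show because they offered no such pair. No separate evidence bears on this result, so it can be described but not explained.

The compounds shown leave open whether this insensitivity extends to other groups on the same ring, such as a hydroxyl, an amine, a chlorine atom or a carboxylic acid in place of methoxy. They also leave open what a plain phenyl ring, with no methoxy group at all, would give here.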